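From 2-vinylphenyl to 2,5-dimethylphenyl on a shared core

The source may report more compounds than this note shows. Statements on the series, on what has been measured and on what is new or still open speak of the compounds shown alone.

Three compounds share one core and differ only in the aromatic group on a saturated ring carbon. In a functional assay (muscle tissue) with Cavia porcellus as the target (on this read-out lower numbers stand for an effect already at smaller amounts and higher numbers for an effect only at larger amounts of compound), compound 1 `COC(=O)C1=C(C)N=C(C)/C(=C(\O)OC)C1c1cccc(O)c1` gives 1000 nM while compound 2 `COC(=O)C1=C(C)N=C(C)/C(=C(\O)OC)C1c1ccc(F)cc1` gives 129 nM and compound 3 `C=Cc1ccccc1C1C(C(=O)OC)=C(C)N=C(C)/C1=C(\O)OC` gives 4.47 nM on the same scale. Compound 3 therefore has the lowest number of the three. The next structure is compound 4 `COC(=O)C1=C(C)N=C(C)/C(=C(\O)OC)C1c1cc(C)ccc1C` and the change is 2,5-dimethylphenyl in place of 2-vinylphenyl on a saturated ring carbon at that same place.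

The measured steps all swap this one group, and they show how much it can matter: a 7.8-fold lower number from compound 1 to compound 2 (0.89 log units; beyond the scatter) was modest, while a 220-fold lower number from compound 1 to compound 3 (2.35 log units; beyond the scatter) and a 29-fold lower number from compound 2 to compound 3 (1.46 log units; beyond the scatter) were large. Like 2-vinylphenyl, the incoming 2,5-dimethylphenyl has a 2 in its name, unlike 3-hydroxyphenyl and 4-fluorophenyl, but it has never been measured here. A modest rise is therefore expected, not a return to the higher numbers. The expected change in this assay is estimated as a 4.5-fold higher number from compound 3 to compound 4 (0.65 log units; beyond the scatter) in size. Compound 4 is expected at about 20 nM with an estimated range from 4 nM to 100 nM for this measurement.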

Compound 4, half-maximal effective concentration: 100 nM
Beside the measured number, compound 4's estimate is 5.0-fold (0.70 log units) below it; the range from low to high includes it.
By their numbers in this assay, from the lowest: compound 3; then compounds 4 and 2 (each within the scatter of the next); then compound 1.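

A 2 in the group's name is not enough to keep the low number of compound 3: in this assay, 2,5-dimethylphenyl in place of 2-vinylphenyl gives a 22-fold higher number from compound 3 to compound 4 (1.35 log units; beyond the scatter) and so loses most of the gap that set 2-vinylphenyl apart. The result of a 1.3-fold lower number from compound 2 to compound 4 (0.11 log units; within the scatter) means that 2,5-dimethylphenyl and 4-fluorophenyl cannot be told apart here, yet a 10-fold lower number from compound 1 to compound 4 (1.00 log units; beyond the scatter) still separates 2,5-dimethylphenyl from 3-hydroxyphenyl. The two groups in the large step have the same count of heavy atoms, and only 2-vinylphenyl has a double bond outside the aromatic ring, so a matching count does not ensure a matching number.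

Nothing available here explains why these groups differ. Also open, as far as these compounds go, is how 2-ethylphenyl, which keeps the two-carbon chain without its double bond, or 2-aminophenyl would read on the shared core.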